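The source may hold more compounds than are shown below. What is called first, only, known or untested is meant among the compounds shown, and "the series" means these compounds.

Compound 1, `Oc1cc(C(F)(F)F)ccc1-c1nc(-c2ccccc2O)n(-c2ccc(Cl)cc2)n1`, gives 68% in a functional assay on PC-12 cells (Rattus norvegicus) for cytotoxicity, read by MTT assay, with stated times of 2 h and 24 h, tested at 1 uM; a higher number here means a stronger effect of the compound at the concentration tested, a lower number a weaker effect.
Compound 2, `Oc1cc(C(F)(F)F)ccc1-c1nc(-c2ccccc2O)n(-c2ccc(Br)cc2)n1`, gives 69.4% in this assay.
Compound 3, `Oc1cc(C(F)(F)F)ccc1-c1nc(-c2ccccc2O)n(-c2ccc(C(F)(F)F)cc2)n1`, gives 70.7% in this assay.

Compound 3 holds the highest of the three numbers, yet its gap to each of the others lies within the scatter, so the three read alike. Compound 4, `N#Cc1ccc(-n2nc(-c3ccc(C(F)(F)F)cc3O)nc2-c2ccccc2O)cc1`, has not been measured; it differs from compound 3 by cyano in place of trifluoromethyl on an aromatic carbon. Among the compounds with values here, the steps that bear on this are the earlier exchanges at the same aromatic carbon: a number 1.4 percentage points higher from compound 1 to compound 2 (within the scatter), a number 2.7 percentage points higher from compound 1 to compound 3 (within the scatter) and a number 1.3 percentage points higher from compound 2 to compound 3 (within the scatter). None of them moved the read-out beyond the scatter. A further exchange at that carbon is therefore expected to change little in this assay. Compound 4 is expected to give 69%, with a range from 59% to 79%. That estimate means a step of a number 1.7 percentage points lower from compound 3 to compound 4 (within the scatter).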

Compound 4, a percentage reported as activity, at one concentration (the size of the read-out at that concentration, not a potency): 66.6%
The estimate for compound 4 lay 2.4 percentage points above the measured number, within the range that was stated.
By their numbers in this assay, from the lowest: compounds 4, 1, 2 and 3 (each within the scatter of the next).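

Cyano brings a hydrogen-bond acceptor and a triple bond that trifluoromethyl lacks, yet in this assay the change stays small, with a number 4.1 percentage points lower from compound 3 to compound 4 (within the scatter), a number 2.8 percentage points lower from compound 2 to compound 4 (within the scatter) and a number 1.4 percentage points lower from compound 1 to compound 4 (within the scatter). So among these four compounds, the read-out at this position also tolerates a group of a different kind from the halogens and trifluoromethyl. No measurement available here gives a reason for this. Still open, going by these compounds, is whether an amine, a carboxylic acid or a longer chain at this position would move the read-out beyond the scatter.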